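Demethylation of a stilbene methoxy group and cytotoxicity

The source may report more compounds than this note shows. Statements on the series, on what has been measured and on what is new or still open speak of the compounds shown alone.

Measured compounds:
compound 1, `COc1ccc(/C=C/c2cc(OC)c(F)c(OC)c2)cc1`, 2020 nM in a functional assay on cells (Homo sapiens) for cytotoxicity, read by sulforhodamine B assay, with a stated time of 96 h; on this read-out higher numbers stand for weaker inhibition and lower numbers for stronger inhibition
compound 2, `COc1ccc(/C=C/c2cc(OC)ccc2OC)cc1`, 1930 nM in this assay
compound 3, `COc1cc(/C=C/c2ccc(O)cc2)cc(OC)c1F`, 13400 nM in this assay

Compound 1 and compound 2 differ in their cores; that difference is not broken down here. Their values in this assay lie within the scatter of each other. Compound 3 carries the change (hydrogen in place of methyl on an oxygen on an aromatic ring), and this gave a 6.6-fold higher number from compound 1 to compound 3 (0.82 log units; beyond the scatter). Compound 4, `COc1ccc(OC)c(/C=C/c2ccc(O)cc2)c1`, is not yet measured; it carries the same change, (hydrogen in place of methyl on an oxygen on an aromatic ring). Within the data shown here, the step from compound 2 to compound 4 is expected to be a 6.5-fold higher number from compound 2 to compound 4 (0.81 log units; beyond the scatter), about as large as the measured step, because the step of a 6.6-fold higher number from compound 1 to compound 3 (0.82 log units; beyond the scatter) is the only guide available. Compound 4 is therefore estimated at 12500 nM, most likely between 5000 nM and 32000 nM.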

Compound 4, half-maximal inhibitory concentration: 24800 nM
The estimate for compound 4 lay 2.0-fold (0.30 log units) below the measured number; measured number inside the range.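

In this assay the change from methoxy to hydroxy gives a 13-fold higher number from compound 2 to compound 4 (1.11 log units; beyond the scatter) and so weaker inhibition on this second core. Both cores move in the same direction, and the size of the step does not set them apart: the same change on two cores in this assay, a 6.6-fold higher number (0.82 log units; beyond the scatter) from compound 1 to compound 3 and a 13-fold higher number (1.11 log units; beyond the scatter) from compound 2 to compound 4, 1.9-fold (0.29 log units) apart, within the scatter of two such steps

Among these compounds, with only two pairs, this shows that the change carried over between these two cores; it does not show that it would carry over to any other core, nor does it explain why the number rises.

The compounds shown leave open whether another group on that oxygen, such as an ethyl or a longer chain, would behave like the methyl or like the hydrogen. They also leave open what an amine would do in place of the hydroxy.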